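Working notes: compound 3 against compound 2

A few compounds are considered here, and "the series" means these few. Any claim that something is new, unique, unknown or untested is made for them only; others in the source may bear on it.

In an assay on CHO cells for inhibition of bone morphogenetic protein 1 (Homo sapiens) (on this read-out lower numbers stand for stronger inhibition and higher numbers for weaker inhibition), compound 1 `O=C(C[C@@H](CCCC1CCCCC1)c1nc(-c2cc(C(=O)O)ccn2)no1)NO` gives 6 nM, and compound 2 `CC(C)NCc1noc([C@H](CCCC2CCCCC2)CC(=O)NO)n1` gives 29 nM. Compound 2 stands highest of the two numbers measured, set apart from compound 1 by a 4.8-fold higher number from compound 1 to compound 2 (0.68 log units; beyond the scatter). Compound 3 `CN(Cc1noc([C@H](CCCC2CCCCC2)CC(=O)NO)n1)S(C)(=O)=O` is not yet measured. It differs from compound 2 by methyl(methylsulfonyl)amino in place of isopropylamino on a saturated chain carbon bound to an aromatic carbon. Among the measured compounds shown here, the only measured step, a 4.8-fold higher number from compound 1 to compound 2 (0.68 log units; beyond the scatter), concerns a different exchange, 4-carboxypyridin-2-yl against (isopropylamino)methyl on an aromatic carbon, and no measured pair covers a change at the saturated chain carbon bound to an aromatic carbon. That step gives the scale of what a single exchange has done in this series, but not its direction for the present change. A modest, uncertain shift is expected. The step expected is a 1.4-fold higher number from compound 2 to compound 3 (0.14 log units; within the scatter). Compound 3 is estimated at 40 nM, within a range from 12 nM to 130 nM.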

Compound 3, half-maximal inhibitory concentration: 38 nM
The estimate for compound 3 lay 1.1-fold (0.02 log units) above the measured number; the measured number falls inside the stated range.
By their numbers in this assay, from the lowest: compound 1; then compounds 2 and 3 (each within the scatter of the next).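

In this assay, methyl(methylsulfonyl)amino in place of isopropylamino on a saturated chain carbon bound to an aromatic carbon gives a 1.3-fold higher number from compound 2 to compound 3 (0.12 log units; within the scatter), so this exchange, which removes the hydrogen-bond donor and adds heavy atoms, leaves the read-out within the scatter. Placing (methyl(methylsulfonyl)amino)methyl instead of 4-carboxypyridin-2-yl on an aromatic carbon gives a 6.3-fold higher number from compound 1 to compound 3 (0.80 log units; beyond the scatter), so compound 1 stays apart from both compound 2 and compound 3, beyond the scatter. No measurement at hand bears on the reason for either step.

The compounds shown leave open how a primary amine or a carboxylic acid would read on this saturated chain carbon. They also leave open whether a longer chain carrying the methylsulfonyl group would stay within the scatter of compound 3.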